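This account rests on a few compounds, and the source may have more. Where it says the series, first, only, none or still open, it means among the compounds named here.

Three compounds share one core that carries two amide arms. Compound 1 `CCCCCCNC(=O)c1[nH]cnc1C(=O)Nc1ccc(Cl)c(Cl)c1` is tested in a functional assay on HL-60 cells (Homo sapiens), with a stated time of 2 days (a higher number here means a weaker inhibitor, a lower number a stronger inhibitor), where compound 1 gives 14600 nM. Compound 3 `COC(=O)[C@H](NC(=O)c1[nH]cnc1C(=O)Nc1ccc(Cl)c(Cl)c1)c1ccccc1` gives 17300 nM in this assay, a reading within the scatter of compound 1. Compound 2 `O=C(NCc1ccc(-c2ccccc2)cc1)c1nc[nH]c1C(=O)Nc1ccc(Cl)c(Cl)c1` gives 7000 nM, a lower number than compound 1 by more than the scatter, so compound 1 holds the second highest number of the three. Compound 4 `CCCN(CCC)C(=O)c1[nH]cnc1C(=O)Nc1ccc(Cl)c(Cl)c1` is not yet measured. It differs from compound 1 in one place: dipropylamino in place of hexylamino on a carbonyl carbon. Among the measured compounds shown here, no measured pair shows a change of this kind, so nothing can be read off directly. The step of a 1.2-fold higher number from compound 1 to compound 4 (0.09 log units; within the scatter) is expected to be small, with no clear direction beyond the scatter. Compound 4 is therefore expected to give about 18000 nM, with a range from 7000 nM to 45000 nM.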

Compound 4, half-maximal inhibitory concentration: 379000 nM
The estimate for compound 4 lay 21-fold (1.32 log units) below the measured number; measured number outside the range, above it.
By their numbers in this assay, from the lowest: compound 2; then compounds 1 and 3 (each within the scatter of the next); then compound 4.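

This position is sensitive to how the same atoms are arranged: dipropylamino in place of hexylamino on a carbonyl carbon gives a 26-fold higher number from compound 1 to compound 4 (1.41 log units; beyond the scatter) as a large step. Hexylamino carries a hydrogen-bond donor and dipropylamino carries none, but the two also differ in how their carbons are arranged, so this one pair cannot separate those two changes. Nothing here explains the step.

Still open, from the compounds shown here alone, is which of the two changes matters. Propylamino, which keeps the amide hydrogen on a shorter chain, and dihexylamino, which lacks it and has longer chains, could help tell them apart.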